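Cyclopropylurea in place of cyclobutylamide on a shared core

A few compounds are considered here, and "the series" means these few. Any claim that something is new, unique, unknown or untested is made for them only; others in the source may bear on it.

Two compounds on the same core have been examined in an assay on isolated protein for inhibition of Gonadotropin-releasing hormone receptor (Homo sapiens); a higher number here means a weaker inhibitor, a lower number a stronger inhibitor. Compound 1, `COc1ccc([N+](=O)[O-])cc1CSc1nc2cc(NC(=O)NC(C)(C)C)ccc2n1C1CC1`, gives 79 nM. Compound 2, `COc1ccc([N+](=O)[O-])cc1CSc1nc2cc(NC(=O)C3CCC3)ccc2n1C(C)C`, gives 1500 nM, the higher of the two numbers and far apart from compound 1, beyond the usual scatter; since compound 1 and compound 2 differ in more than one place, only the two values themselves can be compared. Compound 3, `COc1ccc([N+](=O)[O-])cc1CSc1nc2cc(NC(=O)NC3CC3)ccc2n1C(C)C`, has not yet been measured. It differs from compound 2 in one place: cyclopropylamino in place of cyclobutyl on a carbonyl carbon. Among the compounds with values here, no single-change step between measured compounds is available to guide the size of the expected change. A urea is present in compound 1 as well, which gives 79 nM, so a move toward a lower number is expected, estimated as a 4.3-fold lower number from compound 2 to compound 3 (0.63 log units; beyond the scatter). Compound 3 is expected to give about 350 nM, within a range from 80 nM to 1500 nM.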

Compound 3, half-maximal inhibitory concentration: 1900 nM
For compound 3 the middle estimate is 5.4-fold (0.73 log units) below the measured one; the measured number lies above the stated range.
By their numbers in this assay, from the lowest: compound 1; then compounds 2 and 3 (each within the scatter of the next).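

In this assay, within the data shown here, the first single-change step at this position is a 1.3-fold higher number from compound 2 to compound 3 (0.10 log units; within the scatter), so cyclopropylamino in place of cyclobutyl on a carbonyl carbon does not separate the two compounds. On this core, the exchange brings in a nitrogen and one hydrogen-bond donor, and a three-membered ring replaces a four-membered one, with no difference beyond the scatter. No measurement bears on why these changes leave the two values within the scatter of each other.

Compound 1 differs from compound 3 in more than one place, so the compounds shown cannot say which difference goes with the value of compound 1, 79 nM. They also leave open whether a larger group at this carbonyl carbon, such as cyclopentyl or dimethylamino, would give a value beyond the scatter of compound 2 and compound 3.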